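This account rests on a few compounds, and the source may have more. Where it says the series, first, only, none or still open, it means among the compounds named here.

Series notes. Compound 1 `c1ccc(-c2cn3ccnc3c(-c3ccc4ncn(C5CCCCC5)c4c3)n2)cc1` gives 26.1% in a functional assay on A498 cells (Homo sapiens) for inhibition, read by sulforhodamine B assay, with a stated time of 48 h, tested at 10 uM; on this read-out lower numbers stand for less inhibition and higher numbers for more inhibition at the one concentration tested (going by the name of the read-out). For the measured compounds named here, compound 2 `COc1ccc(-c2cn3ccnc3c(-c3ccc4ncn(C5CCCCC5)c4c3)n2)cc1` gives -12.3% in the same assay, and the single measured step, a number 38.4 percentage points lower from compound 1 to compound 2 (beyond the scatter), is the only one the set offers. On these two numbers compound 2 stands lowest, with compound 1 the nearest measured compound.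

Compound 3 `O=Cc1ccc(-c2cn3ccnc3c(-c3ccc4ncn(C5CCCCC5)c4c3)n2)cc1` is the next member: formyl in place of methoxy on an aromatic carbon. Going by the values given here, the only measured step concerns a methoxy entering in place of hydrogen on the same aromatic carbon; no step in the set exchanges methoxy for formyl, so the direction of the change from compound 2 to compound 3 is not fixed by any measured pair. Because a number 38.4 percentage points lower from compound 1 to compound 2 (beyond the scatter) was large, a substituent at this place evidently matters, and a different substituent is expected to move the number again rather than leave it within the scatter. The expected step is a number 24.3 percentage points higher from compound 2 to compound 3 (beyond the scatter), with wide uncertainty. Compound 3 is therefore estimated at 12%, in the range -20% to 42%.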

Compound 3, a percentage reported as inhibition, at one concentration (the size of the read-out at that concentration, not a potency): 11.2%
For compound 3 the middle estimate is 0.8 percentage points above the measured one, within the range that was stated.
By their numbers in this assay, from the lowest: compound 2; then compound 3; then compound 1.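

With a second substituent at this place, the read-out in this assay proves to depend on which group enters: going from 4-methoxyphenyl to 4-formylphenyl gives a number 23.5 percentage points higher from compound 2 to compound 3 (beyond the scatter) even though the two groups match in heavy atoms and hydrogen-bond acceptors as counted. Formyl does not restore the level of hydrogen, with a number 14.9 percentage points lower from compound 1 to compound 3 (beyond the scatter), so both substituents shown at this place lie lower than hydrogen, and compound 3 falls between compound 2 and compound 1. Nothing measured here accounts for the difference between the two groups.

As far as these compounds go, whether any group at this place can rise above compound 1 stays open, as does where an amine, a carboxylic acid or a longer alkoxy chain would fall. From the compounds shown here alone, all three numbers come from one concentration on one cell line, so the order across a concentration series or on other cells also stays open.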